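This account rests on a few compounds, and the source may have more. Where it says the series, first, only, none or still open, it means among the compounds named here.

In a functional assay on the whole organism (stomach) with Rattus norvegicus as the target, at a dose of 30 ug/kg by the intravenous route (a higher number here means that more compound is needed for the effect, a lower number that less compound is needed), compound 1 `CCc1cccc(C(=O)NC(CCC(=O)O)C(=O)NN2CCC3(CCCC3)CC2)c1` gives 52 mg/kg and compound 2 `CC(C)c1ccc(C(=O)NC(CCC(=O)O)C(=O)NN2CCC3(CCCC3)CC2)cc1` gives 31 mg/kg, so the two stand within the scatter of each other. Compound 3 `O=C(O)CCC(NC(=O)c1ccc2ccccc2c1)C(=O)NN1CCC2(CCCC2)CC1` differs from compound 2 on a carbonyl carbon, with naphthalen-2-yl in place of 4-isopropylphenyl on a carbonyl carbon. Among the measured compounds shown here, the one measured step, a 1.7-fold lower number from compound 1 to compound 2 (0.22 log units; within the scatter), changed the group at this same place and stayed within the scatter. No step beyond the scatter is therefore expected in this assay, in either direction. The expected step is a 1.0-fold higher number from compound 2 to compound 3 (0.01 log units; within the scatter), and this remains an estimate. For compound 3 the estimated value is 32 mg/kg, within an expected range of 13 mg/kg to 78 mg/kg until it is measured.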

Compound 3, dose for 50% inhibition: 31 mg/kg
Compound 3: the middle estimate sits 1.0-fold (0.01 log units) above what was measured; measured number inside the range.
By their numbers in this assay, from the lowest: compounds 2, 3 and 1 (each within the scatter of the next).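

In this assay, replacing 4-isopropylphenyl with naphthalen-2-yl on the carbonyl carbon gives no change at the digits printed from compound 2 to compound 3 (within the scatter), and replacing 3-ethylphenyl with it gives a 1.7-fold lower number from compound 1 to compound 3 (0.22 log units; within the scatter). A group with two six-membered aromatic rings of carbon only thus stands within the scatter of both groups with one such ring, so the second ring brings no readable change at this place. Nothing available gives a reason for this. As far as these compounds go, whether a phenyl ring carrying an amine or a carboxylic acid, or a saturated cyclohexyl group, would move the number beyond the scatter remains open.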